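A few compounds are considered here, and "the series" means these few. Any claim that something is new, unique, unknown or untested is made for them only; others in the source may bear on it.

Compound 1 `O=C(CCCCCc1ccc(O)c(Cl)c1)N1CCOC1=O`: in an assay on HEK293 cells for inhibition of N-acylethanolamine-hydrolyzing acid amidase (Rattus norvegicus), read by LC-MS, with a stated time of 30 min (on this read-out higher numbers stand for weaker inhibition and lower numbers for stronger inhibition), compound 1 reaches only the limit > 20000 nM.
Compound 2 `O=C(CCCCCc1ccc(C(F)(F)F)cc1)N1CCOC1=O`: in this assay compound 2 gives 1040 nM.
Compound 3 `O=C1OCCN1C(=O)c1ccc(Oc2ccc(O)cc2)cc1`: in this assay compound 3 reaches only the limit > 20000 nM.

Compound 3 stands at the edge of the numbers shown. Its result in this assay is a limit of the assay, not a measured number, so nothing more than that is known of it. The same limit holds for compound 1, as the limit of > 20000 nM in this assay, at which 2 of the 3 values shown sit, records. For the measured compounds named here, compound 2 is the only one of the three compounds whose value falls inside the measurable range of this assay.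

Compound 4 `CCCCCCOc1ccc(C(=O)N2CCOC2=O)cc1` differs from compound 3 in one place: hexyl in place of 4-hydroxyphenyl on an oxygen on an aromatic ring. Going by the values given here, no step between two measured compounds is available to set the size of this change, so any expectation rests on the shape of the change and on the spread of the three values. The account expects compound 4 to move away from the limit into the measurable range, and the step from compound 3 to compound 4 is estimated as an at least 3.3-fold lower number from compound 3 to compound 4 (0.52 log units; beyond the scatter). In this assay compound 4 is expected to give about 6000 nM, with a likely range from 1500 nM to 20000 nM, while it remains possible that the assay again reports only a limit.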

Compound 4, half-maximal inhibitory concentration: 640 nM
Estimate against measurement, compound 4: 9.4-fold (0.97 log units) above, outside the stated range (below it).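

At this position, the change from 4-hydroxyphenyl to hexyl, which removes the aromatic ring and the hydrogen-bond donor and acceptor counted on the leaving group, brings an at least 31-fold lower number from compound 3 to compound 4 (1.49 log units; beyond the scatter) in this assay. This is the first pair shown that differs in one place, so it is the first to show that the group on this oxygen alone can separate a compound at the limit from one with a measured value. The size of the step is only a lower bound, because the value of compound 3 is a limit of the assay and not a number: the limit of > 20000 nM in this assay, at which 2 of the 4 values shown sit.

This single pair cannot tell whether the lower number belongs to the hexyl chain itself, to the loss of the hydroxyl, or to the loss of the aromatic ring, as all three change together in this one step. Open too, on these data alone, is how an unsubstituted phenyl, a shorter butyl chain, a longer octyl chain or a hexyl chain ending in an amine or a carboxylic acid would read on this oxygen.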